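Phosphorus configuration and acyl ring shape blood half-life

The source may hold more compounds than are shown below. What is called first, only, known or untested is meant among the compounds shown, and "the series" means these compounds.

The shared core carries a phosphorus stereocentre and an acyloxymethyl ester whose aromatic ring is varied. Compound 3 `COC(=O)CCNC(=O)[C@@H]1O[P@@](=O)(OCOC(=O)c2cc(C)nn2C)OCC1(C)C` and compound 2 `COC(=O)CCNC(=O)[C@@H]1O[P@](=O)(OCOC(=O)c2cc(C)nn2C)OCC1(C)C` differ only as the two compounds have the same atoms and bonds and differ only in configuration as drawn: 1 of 2 stereo elements differ; a stereocentre at a phosphorus is drawn S in compound 3 and R in compound 2. In an ADME assay on blood (Homo sapiens) for pharmacokinetics (on this read-out higher numbers stand for a longer-lived compound and lower numbers for a shorter-lived compound), compound 3 returns a limit of the assay, > 1 h. Compound 2 returns the opposite limit, < 0.16 h. The step of an at least 6.2-fold higher number from compound 2 to compound 3 (0.79 log units; beyond the scatter) thus rests on the fact that compounds 2 and 3 differ only in the configuration as drawn together with the bounds the limit of < 0.16 h in this assay, at which 2 of the 3 values shown sit, and (the limit of > 1 h in this assay, at which 1 of the 3 values shown sits). Compound 1 `COC(=O)CCNC(=O)[C@@H]1O[P@@](=O)(OCOC(=O)c2ccns2)OCC1(C)C` arises from compound 3 by 1,2-thiazol-5-yl in place of 1,3-dimethyl-1H-pyrazol-5-yl on a carbonyl carbon; in this assay compound 1 also returns a limit, < 0.16 h, so an at least 6.2-fold lower number from compound 3 to compound 1 (0.79 log units; beyond the scatter) is read only against the two bounds. Compound 4 `COC(=O)CCNC(=O)[C@@H]1O[P@](=O)(OCOC(=O)c2ccns2)OCC1(C)C` applies the same change to compound 2, (1,2-thiazol-5-yl in place of 1,3-dimethyl-1H-pyrazol-5-yl on a carbonyl carbon), while keeping the phosphorus configuration of compound 2. Compound 4 is expected to give about 0.1 h, within 0.03 h to 0.3 h. The expected step that the limit leaves unreadable from compound 2 to compound 4 is essentially flat, which rests on (the limit of < 0.16 h in this assay, at which 2 of the 3 values shown sit), since that bound already holds both compound 2 and compound 1, the two nearest neighbours of compound 4.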

Compound 4, half-life: < 0.16 h
Compound 4: only a limit was reported (the forecaster's own chance of this, stated with the estimate: 85%); the middle value lies beyond the limit too.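

In this assay compound 4 gives < 0.16 h, a limit of the assay. Compound 1 and compound 2 sit at that same limit, so neither step to compound 4 can be read. Left open is how the half-lives of compound 1, compound 2 and compound 4 actually compare, and whether the phosphorus configuration matters with the 1,2-thiazol-5-yl group.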